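The source may hold more compounds than are shown below. What is called first, only, known or untested is meant among the compounds shown, and "the series" means these compounds.

Measured compounds and values:

Compound 1 `Cc1c(OCCCCOc2ccc(C(=O)O)cc2F)ccc(C(=O)CC2CCCC2)c1O`: in an assay on HEK293 cells for positive allosteric modulation of metabotropic glutamate receptor 3 (Rattus norvegicus), read by thallium flux, with a stated time of 2.5 min (a higher number here means that more compound is needed for the effect, a lower number that less compound is needed), compound 1 gives > 10000 nM, which is a limit of the assay and not a number.
Compound 2 `Cc1c(OCCCCOc2ccc(C(=O)O)cc2F)ccc(C(=O)CC(C)C)c1O`: in this assay compound 2 gives 1420 nM.
Compound 3 `Cc1c(OCCCCOc2ccc(C(=O)O)cc2)ccc(C(=O)CC(C)C)c1C`: in this assay compound 3 gives "not determined" (no result reported).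

Compound 1 therefore stands only at a limit, and it sits at the limit of > 10000 nM in this assay, at which 1 of the 3 values shown sits. Among the compounds with values here, the one measured step, an at least 7.0-fold lower number from compound 1 to compound 2 (0.84 log units; beyond the scatter), concerns a group on a saturated chain carbon bound to a carbonyl carbon, and it shows that a smaller group there brings the number down from the limit.

Compound 4 `COc1ccc(C(=O)O)cc1OCCCCOc1ccc(C(=O)CC2CCCC2)c(O)c1C` differs from compound 1 in another place: 5-carboxy-2-methoxyphenyl in place of 4-carboxy-2-fluorophenyl on an oxygen on a saturated carbon. Within the data shown here, no measured step changes this part of the molecule, so the measured step does not bear on it, and the data give no direction for this change in this assay. Compound 1 itself stands at the limit, so compound 4 is estimated to stay near it. For compound 4 the expected value is 12000 nM, with a range from 2500 nM to 60000 nM. The step this estimate means is expected to be a step that the limit leaves unreadable from compound 1 to compound 4.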

Compound 4, half-maximal effective concentration: 1020 nM
Compound 4: middle estimate off by 12-fold (1.07 log units), on the high side, outside the stated range (below it).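

Within the data shown here, the earlier compounds showed only that the group on the saturated chain carbon bound to a carbonyl carbon matters. In this assay, the group on an oxygen on a saturated carbon matters too, with an at least 9.8-fold lower number from compound 1 to compound 4 (0.99 log units; beyond the scatter), so the cyclopentyl group does not by itself keep a compound out of measurable range: compound 4 carries it and gives 1020 nM. Compound 1 stands at a limit and not at a number, so the full size of this step stays unknown: the limit of > 10000 nM in this assay, at which 1 of the 4 values shown sits.

This change swaps 4-carboxy-2-fluorophenyl for 5-carboxy-2-methoxyphenyl as a whole, and the compounds shown cannot tell whether the methoxy group or the different carboxy placement accounts for the step. Also open, as far as these compounds go, is how the isopropyl group of compound 2 would fare with 5-carboxy-2-methoxyphenyl, and whether an amide could stand in for the carboxylic acid.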